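This account rests on a few compounds, and the source may have more. Where it says the series, first, only, none or still open, it means among the compounds named here.

Compound 1 `COC(=O)c1ccc(NCc2cncn2Cc2ccccc2C)cc1-c1ccccc1`, compound 2 `COC(=O)c1ccc(NCc2cncn2Cc2ccccc2N)cc1-c1ccccc1` and compound 3 `COC(=O)c1ccc(NCc2cncn2Cc2ccc(-c3ccccc3)cc2)cc1-c1ccccc1` share one core and differ only in the group on a saturated chain carbon bound to an aromatic nitrogen. In a toxicity assay on NIH3T3 cells (Mus musculus) for cytotoxicity, read by resazurin assay (on this read-out lower numbers stand for an effect already at smaller amounts and higher numbers for an effect only at larger amounts of compound), compound 1 gives 10000 nM. In this assay compound 2 gives 25000 nM, which is a 2.5-fold higher number from compound 1 to compound 2 (0.40 log units; beyond the scatter). For compound 3 the assay reports only a limit, > 1000 nM, so that compound 3 stands at a limit and not at a number, as the limit of > 1000 nM in this assay, at which 1 of the 3 values shown sits, records. Compound 4 `COC(=O)c1ccc(NCc2cncn2Cc2ccccc2C#N)cc1-c1ccccc1` carries 2-cyanophenyl in place of 4-phenylphenyl on a saturated chain carbon bound to an aromatic nitrogen. The two measured steps that lead to compound 3, a step that the limit leaves unreadable from compound 1 to compound 3 and a step that the limit leaves unreadable from compound 2 to compound 3, cannot be sized, so no readable step bears directly on the change to compound 4. Its 2-cyanophenyl is closer in build to the 2-methylphenyl of compound 1 and the 2-aminophenyl of compound 2 than to the 4-phenylphenyl of compound 3. Compound 4 is therefore expected to give 15000 nM in this assay, with a range from 4000 nM to 50000 nM. The step this estimate implies, a step that the limit leaves unreadable from compound 3 to compound 4, is expected to be read against a limit and so cannot be judged against the scatter.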

Compound 4, half-maximal effective concentration: 25000 nM
Compound 4: middle estimate off by 1.7-fold (0.22 log units), on the low side, within the range that was stated.
By their numbers in this assay, from the lowest: compound 1; then compounds 2 and 4 (each within the scatter of the next).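

In this assay, cyano in place of amino on an aromatic carbon gives no change at the digits printed from compound 2 to compound 4 (within the scatter), so these two groups cannot be told apart here, with the step within the scatter. Cyano in place of methyl gives a 2.5-fold higher number from compound 1 to compound 4 (0.40 log units; beyond the scatter), a modest step beyond the scatter, which repeats the step seen with amino and leaves the 2-methylphenyl of compound 1 apart from both other groups. Compound 3 stands at a limit and not at a number, so its steps, including the one to compound 4, cannot be read: the limit of > 1000 nM in this assay, at which 1 of the 4 values shown sits.

The compounds shown leave open how a methoxy or a carboxylic acid in place of the cyano on that aromatic carbon would read. They also leave open how far a plain phenyl on the saturated chain carbon would fall from compound 1 and compound 4.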